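The compounds below may be only part of what the source reports. "The series", "measured", "known", "first", "only" and "open" are said of these compounds alone.

Measured so far:
- Compound 1, `O=C(CCC1=CCN(Cc2ccc(C(F)(F)F)cc2)C1=O)NO`: 4540 nM
- Compound 2, `COc1cccc(CN2CC=C(CCC(=O)NO)C2=O)c1`: 2820 nM

Both compounds share the same core and were tested in a functional assay on HCT-15 cells (Homo sapiens) for antiproliferative activity; on this read-out lower numbers stand for stronger inhibition of growth and higher numbers for weaker inhibition of growth. Compound 1 gives 4540 nM, the higher of the two numbers, and compound 2 gives 2820 nM; the gap between them lies within the usual scatter of this assay, so no order between the two can be claimed.

Compound 3, `COc1ccc(CN2CC=C(CCC(=O)NO)C2=O)cc1`, has not yet been measured. It differs from compound 1 by methoxy in place of trifluoromethyl on an aromatic carbon. Going by the values given here, no measured pair shows a comparable single change, so the size of the step is uncertain. Given that compound 2, which also carries a methoxy group, gives 2820 nM, compound 3 is expected to land near the two known numbers rather than far from them, with a small step, if any, toward a lower value. Compound 3 is therefore estimated at 3000 nM, within 1200 nM to 7500 nM, which means an expected step of a 1.5-fold lower number from compound 1 to compound 3 (0.18 log units; within the scatter).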

Compound 3, concentration for 50% growth inhibition: 1720 nM
For compound 3 the middle estimate is 1.7-fold (0.24 log units) above the measured one, and the stated range covers the measured number.
By their numbers in this assay, from the lowest: compounds 3, 2 and 1 (each within the scatter of the next, the first and the last beyond it).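

In this assay, going by these compounds alone, the swap of trifluoromethyl for methoxy, on an aromatic carbon para to a large group, is the first single change that can be read on its own (a 2.6-fold lower number from compound 1 to compound 3 (0.42 log units; beyond the scatter)). It shows that the group at this position can move the number beyond the usual scatter, although the step is modest, and that methoxy is accepted here with no loss of growth inhibition. No measurement shown gives a reason for this step.

Within the data shown here, with only two groups compared at this position, it stays open whether the step comes from losing trifluoromethyl or from gaining methoxy. An amine, a carboxylic acid or a longer ether chain at the same carbon would show whether the trend extends beyond this single pair.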